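The source may hold more compounds than are shown below. What is called first, only, known or untested is meant among the compounds shown, and "the series" means these compounds.

Measured compounds:

- Compound 1, `Cn1c(=O)[nH]c2ccc(OCc3cccc(F)c3)cc21`: 5.36%
- Compound 2, `O=C1Nc2ccc(OCc3cccc(Cl)c3)cc2C1=O`: 93%

In an assay on cells for inhibition of Amine oxidase [flavin-containing] B (Homo sapiens), read by fluorescence, with stated times of 30 min and 15 min, tested at 1 uM (a lower number here means less inhibition, a higher number more inhibition at the concentration tested (going by the name of the read-out)), compound 1 gives 5.36%, the lowest of the two numbers recorded. Within the data shown here, the only other measured compound, compound 2, gives 93% in this assay, a reading far higher and well beyond the scatter; compound 2 differs from compound 1 in more than one place, so the two values are simply noted side by side and no step is drawn between them.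

The next compound in the series, compound 3, has the structure `Cn1c(=O)[nH]c2ccc(OCc3cccc(Cl)c3)cc21`. Against compound 1 the change is chloro in place of fluoro on an aromatic carbon. Among the measured compounds shown here, no measured pair in the set reports the effect of this exchange on its own, so the size of the step is open. Compound 2 shows that a chloro-bearing analogue can reach a high inhibition in this assay, but its core differs from compound 1 and gives no direct guidance.

For compound 3 the estimated step from compound 1 is a number 12.6 percentage points higher from compound 1 to compound 3 (beyond the scatter), a modest rise expected, not firmly beyond the scatter. Compound 3 is therefore expected to give about 18%, within the range 2% to 55%.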

Compound 3, a percentage reported as inhibition, at one concentration (the size of the read-out at that concentration, not a potency): 8.89%
Compound 3: the middle estimate sits 9.1 percentage points above what was measured; the measured number falls inside the stated range.
By their numbers in this assay, from the lowest: compounds 1 and 3 (each within the scatter of the next); then compound 2.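

In this assay, among these compounds, chloro in place of fluoro on an aromatic carbon, meta to a large group, gives a number 3.5 percentage points higher from compound 1 to compound 3 (within the scatter) and this is the first step that can be read on its own. On the shared core of compound 1 and compound 3, then, the exchange of one halogen for the other stays within the usual scatter, and neither compound comes near a high inhibition at the single concentration tested. No measurement in hand bears on the reason for this result.

Still open, going by these compounds, is whether a different group at this place on the ring, such as a methoxy, a nitrile or an amine, would move the reading beyond the scatter on this core. Among the compounds shown here, also open is which structural difference goes with the high reading of compound 2 at 93% and no single-place step links that compound to compound 1 or compound 3, so a chloro-bearing or fluoro-bearing intermediate between the two cores would be needed to separate the contributions.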